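This account rests on a few compounds, and the source may have more. Where it says the series, first, only, none or still open, it means among the compounds named here.

Measured so far:
Compound 1 `CCCCCCCCOC(=O)c1c(C(C)(C)O)nc(CCC)n1Cc1ccc(-c2ccccc2C2=NNNN2)cc1` — in an ADME assay on a cell-free system (plasma, Rattus norvegicus, strain Sprague-Dawley) for metabolic stability, with a stated time of 30 min, tested at 50 mg/mL (on this read-out higher numbers stand for a more stable compound and lower numbers for a less stable compound), compound 1 gives 90.2%.
Compound 2 `CCCc1nc(C(C)(C)O)c(C(=O)NCCCCCCC(=O)O)n1Cc1ccc(-c2ccccc2C2=NNNN2)cc1` — in this assay compound 2 gives 97.5%.

Of the two numbers, compound 2 stands nearest to compound 1, separated by a number 7.3 percentage points higher from compound 1 to compound 2 (within the scatter), which lies within the scatter. Compound 3 `CCCc1nc(C(C)(C)O)c(C(=O)OCCCCCC[N+](=O)[O-])n1Cc1ccc(-c2ccccc2C2=NNNN2)cc1` differs from compound 2 by (6-nitrohexyl)oxy in place of (6-carboxyhexyl)amino on a carbonyl carbon. Among the measured compounds shown here, only the step from compound 1 to compound 2 bears on this change at the same carbonyl carbon, and it stayed within the scatter, so no step beyond the scatter is expected in this assay. For compound 3 the estimate in this assay is 90%, ranging from 76% to 100%, which means an expected step of a number 7.5 percentage points lower from compound 2 to compound 3 (within the scatter).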

Compound 3, percent of the compound remaining: 100%
Estimate against measurement, compound 3: 10 percentage points below; the range from low to high includes it.
By their numbers in this assay, from the lowest: compounds 1, 2 and 3 (each within the scatter of the next).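

Compound 3 shows that a third group on this carbonyl carbon also stays within the scatter in this assay: (6-nitrohexyl)oxy in place of (6-carboxyhexyl)amino gives a number 2.5 percentage points higher from compound 2 to compound 3 (within the scatter) and nitro in place of ethyl on the saturated chain gives a number 9.8 percentage points higher from compound 1 to compound 3 (within the scatter). All three groups shown at this place therefore read alike, and nothing available explains this. As far as these compounds go, it remains open whether an amine or a carboxylic acid in place of nitro on the ester chain, or a longer chain, would also stay within the scatter in this assay.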